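The source may hold more compounds than are shown below. What is called first, only, known or untested is meant among the compounds shown, and "the series" means these compounds.

Among the three measured compounds, compound 2 `Cc1nc(N(C)C(=O)NC(=O)c2ccc(Cl)cc2Cl)sc1C(=O)N/N=C/c1ccc(C(F)(F)F)cc1` gives the highest number in a functional assay on MCF7 cells (Homo sapiens) for inhibition, read by MTT assay, with a stated time of 72 h (on this read-out lower numbers stand for stronger inhibition and higher numbers for weaker inhibition), at 24.5 ug/mL. Compound 1 `CN(C(=O)NC(=O)c1ccc(Cl)cc1Cl)c1nc(C(F)(F)F)c(C(=O)N/N=C/c2ccc(C(F)(F)F)cc2)s1` gives 8.42 ug/mL in this assay, and compound 3 `CN(C(=O)NC(=O)c1c(F)cccc1F)c1nc(C(F)(F)F)c(C(=O)N/N=C/c2cc(C(F)(F)F)cc(C(F)(F)F)c2)s1` gives 6.85 ug/mL. Within the data shown here, the only single-point step measured so far is a 2.9-fold higher number from compound 1 to compound 2 (0.46 log units; beyond the scatter), which concerns a different part of the molecule from the change now considered.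

Compound 4 `Cc1nc(N(C)C(=O)NC(=O)c2c(F)cccc2F)sc1C(=O)N/N=C/c1ccc(C(F)(F)F)cc1` differs from compound 2 by 2,6-difluorophenyl in place of 2,4-dichlorophenyl on a carbonyl carbon. Among the measured compounds shown here, no measured pair isolates this exchange. Compound 3 does carry the 2,6-difluorophenyl group, but it also differs from compound 1 elsewhere, so those two values, which lie within the usual scatter of each other, can only hint that the two aryl groups behave similarly here. On that basis, compound 4 is expected to give a number close to that of compound 2, with the step of a 1.4-fold lower number from compound 2 to compound 4 (0.13 log units; within the scatter) estimated as small or within the scatter. The estimate for compound 4 in this assay is 18 ug/mL, with a range from 8 ug/mL to 40 ug/mL.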

Compound 4, half-maximal inhibitory concentration: 30.6 ug/mL
Compound 4: the middle estimate sits 1.7-fold (0.23 log units) below what was measured; low and high end bracket the measured number.
By their numbers in this assay, from the lowest: compounds 3 and 1 (each within the scatter of the next); then compounds 2 and 4 (each within the scatter of the next).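

This pair isolates the exchange of 2,4-dichlorophenyl for 2,6-difluorophenyl on a carbonyl carbon, and the result is a 1.2-fold higher number from compound 2 to compound 4 (0.10 log units; within the scatter) in this assay. Among these compounds, with everything else held constant, the two aryl groups cannot be told apart by this read-out, at least in this one setting, which the earlier compounds could not show because none of them changes this group alone. No measurement bears on why the two groups read alike.

As far as these compounds go, it remains open whether the same holds when trifluoromethyl replaces methyl on the aromatic carbon of the core, as in compound 1. Only halogen-bearing phenyl groups appear on this carbonyl carbon, so the effect of an unsubstituted phenyl, a pyridine ring or a cyclohexyl group there is also unknown.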